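Piperidinyl Amide Follows a Cyclohexylamino Lead

This account rests on a few compounds, and the source may have more. Where it says the series, first, only, none or still open, it means among the compounds named here.

Compound 2 `COc1cc2c(cc1OC)C(CC(=O)NC1CCCCC1)CC2` and compound 1 `CCN(CC)C(=O)CC1CCc2cc(OC)c(OC)cc21` share one core and differ only in the amine part of the amide. Going by the values given here, in a functional assay on the whole organism (strain Wistar) for inhibition, with Rattus norvegicus as the target, read by paw edema, with stated times of 60 min and 24 h, at a dose of 100 mg/kg by the oral route (a higher number here means more inhibition at the dose given (going by the name of the read-out), a lower number less inhibition), compound 1 gives 16.7%, and compound 2 gives 53.3%, the higher of the two numbers; the single step of a number 36.6 percentage points higher from compound 1 to compound 2 (beyond the scatter) is the one comparison available. Compound 3 `COc1cc2c(cc1OC)C(CC(=O)N1CCCCC1)CC2` carries the change (piperidin-1-yl in place of cyclohexylamino on a carbonyl carbon). This change bears on the earlier step, since both alter the group on the carbonyl carbon, and the earlier step was large. Among the compounds with values here, a group with no hydrogen-bond donor, as in compound 1 with 16.7%, leads to the expectation of a drop for compound 3, though of uncertain size given that only one step is known. Compound 3 is therefore estimated at 25%, in the range 5% to 48%. The step of a number 28.3 percentage points lower from compound 2 to compound 3 (beyond the scatter) is the expected change.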

Compound 3, a percentage reported as inhibition, in the whole organism at one dose (the size of the read-out at that dose, not a potency): 40%
Compound 3: the middle estimate sits 15 percentage points below what was measured; measured number inside the range.
By their numbers in this assay, from the lowest: compound 1; then compound 3; then compound 2.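

In this assay the amine part of the amide turns out to be more than a choice between keeping and losing the amide hydrogen. Placing piperidin-1-yl on the carbonyl carbon gives a number 13.3 percentage points lower from compound 2 to compound 3 (beyond the scatter) and so costs part of the number seen with cyclohexylamino, yet the same group also gives a number 23.3 percentage points higher from compound 1 to compound 3 (beyond the scatter) against diethylamino. Compounds without the amide hydrogen can therefore differ clearly from one another, and the group's ring or open chain form goes along with that difference among these three compounds.

On these data alone, whether a pyrrolidin-1-yl, a morpholin-4-yl or a cyclopentylamino group on the same carbonyl carbon would fall in with this order remains open. No measurement is available that explains why the three numbers differ.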